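Branching the Side Chain on a High-Clearance Dipeptide Analogue

The source may hold more compounds than are shown below. What is called first, only, known or untested is meant among the compounds shown, and "the series" means these compounds.

Measured so far in an in vitro ADME assay on microsomes from liver (Canis lupus familiaris) for metabolic stability; a higher number here means faster removal of the compound, a lower number slower removal:
- compound 1, `CC[C@H](C)[C@@H]1C(=O)N[C@H](C2Cc3ccccc3C2)C(=O)N1[C@@H](C(=O)N1CCOCC1)c1ccc(C)nc1`: 2 mL.min-1.g-1
- compound 2, `Cc1ccc([C@H](C(=O)N(C)C)N2C(=O)[C@@H](C3Cc4ccccc4C3)NC(=O)[C@H]2CC(C)C)cn1`: 3000 mL.min-1.g-1
- compound 3, `CC[C@H](C)[C@@H]1C(=O)N[C@H](C2Cc3ccccc3C2)C(=O)N1[C@@H](C(=O)NC)c1cnc(C)cc1C`: 4 mL.min-1.g-1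

Compound 2 stands at the top of the three numbers in this assay; the nearest to it is compound 3 and the furthest is compound 1, and both of those gaps lie well beyond the scatter. Within the data shown here, no single-change step connects compound 2 to either of the other two, so their values are known only as points, not as steps from it.

Compound 4, `CCC(CC)[C@@H]1C(=O)N[C@H](C2Cc3ccccc3C2)C(=O)N1[C@@H](C(=O)N(C)C)c1ccc(C)nc1`, has not yet been measured. It differs from compound 2 in one place:

pentan-3-yl in place of isobutyl on a saturated ring carbon

Among the measured compounds shown here, with no measured step of this kind available, the expectation rests on compound 2 alone, whose value 3000 mL.min-1.g-1 sets the starting point. The move from compound 2 to compound 4 is expected to be a modest step downward, a 2.5-fold lower number from compound 2 to compound 4 (0.40 log units; beyond the scatter), though a result within the scatter would not surprise. For compound 4 the estimated clearance is 1200 mL.min-1.g-1, with a range from 200 mL.min-1.g-1 to 4000 mL.min-1.g-1.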

Compound 4, intrinsic clearance in microsomes: 1 mL.min-1.g-1
The estimate for compound 4 lay 1200-fold (3.08 log units) above the measured number; the whole stated range lies above it.
By their numbers in this assay, from the lowest: compounds 4, 1 and 3 (each within the scatter of the next, the first and the last beyond it); then compound 2.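

In this assay the replacement of isobutyl by pentan-3-yl on the saturated ring carbon gives a 3000-fold lower number from compound 2 to compound 4 (3.48 log units; beyond the scatter) as the first single-change step among these compounds. It shows that this one position, with the rest of the structure held constant, can carry a step far beyond the scatter, even though the change adds only one carbon and no hydrogen-bond donor, acceptor or charge. No evidence is available to explain why a change of this kind produces a step of this size. From the compounds shown here alone, the step rests on a single pair, so it remains open whether a straight pentyl chain or a cyclohexyl group at this ring carbon would give a similarly low number. Also open, going by these compounds, is whether the same replacement would produce a comparable step with a different amide on the shared core.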